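The source may hold more compounds than are shown below. What is called first, only, known or untested is meant among the compounds shown, and "the series" means these compounds.

Going by the values given here, in a physicochemical assay for lipophilicity (on this read-out higher numbers stand for higher lipophilicity and lower numbers for lower lipophilicity), compound 1 (`CCn1c(=O)c2nc(-c3ccc(S(=O)(=O)NCCN(C)C)cc3)[nH]c2n(CC)c1=O`) gives 2.57 and sits at the lower of the two numbers so far. Compound 2 (`CCCn1c(=O)c2nc(-c3ccc(Cl)cc3N)[nH]c2n(CCC)c1=O`) gives 4.02, and the gap between these two numbers lies outside the scatter. Compound 3 (`CCn1c(=O)c2nc(-c3ccc(S(=O)(=O)O)cc3)[nH]c2n(CC)c1=O`) differs from compound 1 by hydroxy in place of (2-(dimethylamino)ethyl)amino on a sulfonyl sulfur and thus has hydroxy in place of (2-(dimethylamino)ethyl)amino on a sulfonyl sulfur. Among the compounds with values here, no measured pair of compounds shows this change, so any forecast remains a judgement. A downward move beyond the scatter is expected, with an estimated step of a number 1.17 log units lower from compound 1 to compound 3 (beyond the scatter) in this direction. The expected value for compound 3 is 1.4 (range 0.3 to 2.4).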

Compound 3, partition coefficient: 0.97
Compound 3: middle estimate off by 0.43 log units, on the high side; the range from low to high includes it.
By their numbers in this assay, from the lowest: compound 3; then compound 1; then compound 2.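

In this assay, going by these compounds alone, hydroxy in place of (2-(dimethylamino)ethyl)amino on the sulfonyl sulfur gives a number 1.60 log units lower from compound 1 to compound 3 (beyond the scatter) and is the first single-place step, since compound 1 and compound 2 differ in more than one place. It shows that this substituent on the sulfonyl sulfur can shift the read-out well beyond the scatter. Nothing available explains the size of this step. The compounds shown leave open how a plain amino group, a methylamino group or a longer aminoalkyl chain on the sulfonyl sulfur would read, and how a carboxylic acid would compare with the sulfo group.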